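Swapping morpholin-4-yl for pyrrolidin-1-yl in compound 3

The source may report more compounds than this note shows. Statements on the series, on what has been measured and on what is new or still open speak of the compounds shown alone.

- compound 1 `COc1cc(N2CCN(Cc3ccccn3)CC2)ccc1Nc1nc(NC2CCCCC2)c2nc[nH]c2n1`: 976 10^-6 cm/s
- compound 2 `COc1cc(N2CCC(C(=O)N3CCOCC3)CC2)ccc1Nc1nc(NC2CCCCC2)c2nc[nH]c2n1`: 744 10^-6 cm/s
- compound 3 `COc1cc(N2CCC(CC(=O)N3CCOCC3)CC2)ccc1Nc1nc(NC2CCCCC2)c2nc[nH]c2n1`: 409 10^-6 cm/s

All three compounds were measured in an ADME assay for permeability, using PAMPA; a higher number here means that the compound crosses the layer faster, a lower number that the compound crosses the layer more slowly. In this assay compound 3 gives 409 10^-6 cm/s. That number lies within the scatter of compound 2, while compound 1 stands above it by more than the scatter.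

The next compound to be measured is compound 4 `COc1cc(N2CCC(CC(=O)N3CCCC3)CC2)ccc1Nc1nc(NC2CCCCC2)c2nc[nH]c2n1`. It has pyrrolidin-1-yl in place of morpholin-4-yl on a carbonyl carbon.

Within the data shown here, no measured step makes this exchange, so the evidence is thin. The nearest step is a 1.8-fold lower number from compound 2 to compound 3 (0.26 log units; within the scatter). That step puts ((morpholin-4-yl)carbonyl)methyl in place of (morpholin-4-yl)carbonyl on a saturated ring carbon, which is a different change, and it stayed within the scatter. Among the measured compounds shown here, with only that step to go on, and with the value of compound 3 at 409 10^-6 cm/s as the starting point, no step beyond the scatter is expected in this assay. The estimated step is a 1.2-fold higher number from compound 3 to compound 4 (0.07 log units; within the scatter). For compound 4 the expected value is 480 10^-6 cm/s, within an estimated range from 240 10^-6 cm/s to 950 10^-6 cm/s.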

Compound 4, apparent permeability: 1690 10^-6 cm/s
Compound 4: the middle estimate sits 3.5-fold (0.55 log units) below what was measured, outside the stated range (above it).
By their numbers in this assay, from the lowest: compounds 3, 2, 1 and 4 (each within the scatter of the next, the first and the last beyond it).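

In this assay, among these compounds, the group on this carbonyl carbon proves to matter: pyrrolidin-1-yl in place of morpholin-4-yl gives a 4.1-fold higher number from compound 3 to compound 4 (0.62 log units; beyond the scatter), whereas the only earlier step, which lengthened the link to the amide, stayed within the scatter. The exchange takes out the ring oxygen, one heavy atom and the one hydrogen-bond acceptor of the leaving group, and it also carries the longer chain past the compound with the shorter morpholine amide, with a 2.3-fold higher number from compound 2 to compound 4 (0.36 log units; beyond the scatter). No measurement at hand bears on why the number moves so far with this exchange.

On these data alone, it remains open whether the step follows the loss of the ring oxygen or the smaller ring, and a piperidin-1-yl group on the same carbonyl carbon would separate the two. As far as these compounds go, it also remains open whether the exchange carries over to the shorter chain, as (pyrrolidin-1-yl)carbonyl on the saturated ring carbon, and how an open-chain dimethylamino group would behave on this carbonyl carbon.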